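The compounds below may be only part of what the source reports. "The series", "measured", "known", "first", "only" and "open" are said of these compounds alone.

Measured so far:
- compound 1 `O=C(CSc1snnc1-c1ccc(Br)cc1Br)Nc1ccccc1` — 24800 nM
- compound 2 `Cc1cccc(NC(=O)CSc2snnc2-c2ccc(Br)cc2Br)c1C` — 241000 nM
- compound 3 `O=C(CSc1snnc1-c1ccc(Br)cc1Br)Nc1ccccc1Cl` — a limit, > 240000 nM

In an ADME assay on MT4 cells (Homo sapiens) for cytotoxicity, read by MTT assay, with a stated time of 5 days (on this read-out lower numbers stand for higher toxicity in this test and higher numbers for lower toxicity in this test), compound 1 gives 24800 nM and holds the lowest of the two numbers shown. Compound 2 gives 241000 nM in this assay, a step of a 9.7-fold higher number from compound 1 to compound 2 (0.99 log units; beyond the scatter). Compound 3 sits at the limit of this assay, > 240000 nM; the step of an at least 9.6-fold higher number from compound 1 to compound 3 (0.98 log units; beyond the scatter) is therefore read only as a floor. Between compound 2 and compound 3 the step that the limit leaves unreadable from compound 2 to compound 3 cannot be sized, owing to the limit of > 240000 nM in this assay, at which 1 of the 3 values shown sits.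

Compound 4 `Cc1ccc(NC(=O)CSc2snnc2-c2ccc(Br)cc2Br)cc1` is not yet measured. It differs from compound 1 by methyl in place of hydrogen on an aromatic carbon. Both steps away from compound 1 that are known changed the same aromatic ring on the amide-type nitrogen, and both raised the number in this assay well beyond the scatter: a 9.7-fold higher number from compound 1 to compound 2 (0.99 log units; beyond the scatter) and an at least 9.6-fold higher number from compound 1 to compound 3 (0.98 log units; beyond the scatter). The change to compound 4 is of the same kind, a single small group added to that ring, so a higher number than compound 1 is expected, though the two steps known do not show whether a single methyl moves the number as far as the larger changes did. The expected step is a 4.0-fold higher number from compound 1 to compound 4 (0.61 log units; beyond the scatter). For compound 4 the estimate in this assay is 100000 nM, with a range from 30000 nM to 300000 nM.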

Compound 4, half-maximal cytotoxic concentration: 24000 nM
Estimate against measurement, compound 4: 4.2-fold (0.62 log units) above; the measured number lies below the stated range.
By their numbers in this assay, from the lowest: compounds 4 and 1 (each within the scatter of the next); then compound 2.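

In this assay methyl in place of hydrogen on an aromatic carbon, para to a large group, leaves the number where it was, within the scatter (a 1.0-fold lower number from compound 1 to compound 4 (0.01 log units; within the scatter)). An added group on this ring therefore does not by itself raise the number, and the 4-methylphenyl amide stands well apart from the 2,3-dimethylphenyl amide (a 10-fold lower number from compound 2 to compound 4 (1.00 log units; beyond the scatter)) and from the 2-chlorophenyl amide (an at least 10-fold lower number from compound 3 to compound 4 (1.00 log units; beyond the scatter)). That last step reads only as a floor, as compound 3 stands at a limit: the limit of > 240000 nM in this assay, at which 1 of the 4 values shown sits.

The compounds shown leave open whether the higher numbers follow the identity of the added group, the number of added groups or their place on the ring, as each of the higher-number compounds differs from the 4-methylphenyl amide in more than one of these. Also open, going by these compounds, is how a methoxy group, a carboxylic acid, a dimethylamino group or a longer chain such as propyl on this ring would read in this assay.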